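A few compounds are considered here, and "the series" means these few. Any claim that something is new, unique, unknown or untested is made for them only; others in the source may bear on it.

Working notes on the series.

Two compounds carry numbers in an assay on isolated protein for inhibition of Amine oxidase [flavin-containing] A (Rattus norvegicus) (on this read-out higher numbers stand for weaker inhibition and lower numbers for stronger inhibition), so far. Compound 1 `c1ccc(CNCc2cn(Cc3ccccc3)c3ccccc23)cc1` gives 244000 nM in this assay. Compound 2 `C#CCNCc1cc2ccccc2n1C` gives 240 nM in this assay, the lower of the two numbers; the gap from compound 1 to compound 2 lies well beyond the scatter, so compound 2 stands as the stronger inhibitor of the pair. Within the data shown here, no step between two measured compounds that differ in a single place is available, so nothing can yet be said about how any one change shifts the numbers.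

Compound 3 `C#CCN(Cc1ccccc1)Cc1cc2ccccc2n1C` has not been measured in this assay. It differs from compound 2 in one place: benzyl in place of hydrogen on an amine nitrogen. Among the measured compounds shown here, no measured pair shows this change, so the expected step rests on the structural change alone. The step from compound 2 to compound 3 is expected to be a modest weakening, a 2.5-fold higher number from compound 2 to compound 3 (0.40 log units; beyond the scatter), not far outside the scatter. For compound 3 the estimate in this assay is 600 nM, within the range 150 nM to 3000 nM.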

Compound 3, inhibition constant: 10000 nM
Compound 3: middle estimate off by 17-fold (1.22 log units), on the low side; measured number outside the range, above it.
By their numbers in this assay, from the lowest: compound 2; then compound 3; then compound 1.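

In this assay, among these compounds, the amine nitrogen of compound 2 turns out to be sensitive to substitution: benzyl in place of hydrogen gives a 42-fold higher number from compound 2 to compound 3 (1.62 log units; beyond the scatter), a large step beyond the scatter and the first single-place change that can be read. The hydrogen on this nitrogen, whose other neighbours are saturated chain carbons, therefore matters to the number, at least on this core, and its replacement by benzyl costs much of the inhibition seen for compound 2. Nothing available explains the size of this step.

As far as these compounds go, whether this loss is specific to benzyl or follows from any substitution on this nitrogen remains open, and a methyl, an ethyl or a phenethyl group at the same place would separate these readings. From the compounds shown here alone, it also remains open whether the step carries over to other cores, and how a hydrogen or a methyl group in place of the propargyl group on this nitrogen would shift the number in this assay.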